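The source may report more compounds than this note shows. Statements on the series, on what has been measured and on what is new or still open speak of the compounds shown alone.

Compound 1 `CC(C)c1ccc(-c2nc(SCc3cn(CC(=O)NC(=O)Nc4ccccn4)nn3)nc(Nc3ccc(F)cc3)c2C#N)cc1` gives 17500 nM in a functional assay on MGC-803 cells (Homo sapiens) for inhibition, read by MTT assay, with a stated time of 72 h; on this read-out higher numbers stand for weaker inhibition and lower numbers for stronger inhibition.
Compound 2 `CC(C)c1ccc(-c2nc(SCc3cn(CC(=O)NC(=O)Nc4ccccn4)nn3)nc(Nc3cccc(Cl)c3)c2C#N)cc1` gives only a limit in this assay, > 64000 nM.

Compound 2 therefore stands at the weak end of the two values, at the limit of > 64000 nM in this assay, at which 1 of the 2 values shown sits, after the step of an at least 3.6-fold higher number from compound 1 to compound 2 (0.56 log units; beyond the scatter). Compound 3 `CC(C)c1ccc(-c2nc(SCc3cn(CC(=O)NC(=O)Nc4ccccn4)nn3)nc(Nc3cccc(C(F)(F)F)c3)c2C#N)cc1` differs from compound 2 by trifluoromethyl in place of chloro on an aromatic carbon. Among the compounds with values here, no measured step exchanges chloro for trifluoromethyl, so the single measured step gives no direct guide to the size of this one. Compound 3 is expected to remain near the limit, a step that the limit leaves unreadable from compound 2 to compound 3. The estimate for compound 3 is 80000 nM, within 25000 nM to 250000 nM.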

Compound 3, half-maximal inhibitory concentration: > 64000 nM
Compound 3: no number, only a limit (the forecaster's own chance of this, stated with the estimate: 70%); the middle value lies beyond the limit too.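

Compound 3 gives only a limit in this assay, > 64000 nM. With trifluoromethyl as with chloro, the 3-substituted phenyl group on this nitrogen gives no readable number, and 3-(trifluoromethyl)phenyl in place of 4-fluorophenyl gives an at least 3.6-fold higher number from compound 1 to compound 3 (0.56 log units; beyond the scatter). The step from chloro to trifluoromethyl cannot be read, and the series now stands as follows: the limit of > 64000 nM in this assay, at which 2 of the 3 values shown sit.

The compounds shown leave open whether the change from compound 1 follows the place on the phenyl ring or the group itself, which 3-fluorophenyl or 4-chlorophenyl would separate. They also leave open whether an amine or a methoxy group in place of trifluoromethyl would give a readable number.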